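The compounds below may be only part of what the source reports. "The series", "measured", "known", "first", "only" and "open" are said of these compounds alone.

Compound 3 `Cc1nc(S(C)(=O)=O)ccc1Oc1ncnc(OC2CCN(C(=O)C(F)(F)F)CC2)c1F` gives 880 nM in a functional assay on isolated protein for inhibition of Glucose-dependent insulinotropic receptor (Rattus norvegicus), read by HTRF and cAMP accumulation (on this read-out lower numbers stand for an effect already at smaller amounts and higher numbers for an effect only at larger amounts of compound), and stands second highest of the three numbers. Compound 1 `Cc1nc(S(C)(=O)=O)ccc1Oc1ncnc(OC2CCN(C(=O)O[C@@H](C)CF)CC2)c1F` gives 1680 nM in this assay, and compound 2 `CCC1(OC(=O)N2CCC(Oc3ncnc(Oc4ccc(S(C)(=O)=O)nc4C)c3F)CC2)CC1` gives 333 nM. Compound 4 `Cc1nc(S(C)(=O)=O)ccc1Oc1ncnc(OC2CCN(C(=O)c3noc(C(C)(C)F)n3)CC2)c1F` is not yet measured; it differs from compound 3 by a group of 9 heavy atoms (5 carbon, 2 nitrogen, 1 oxygen, 1 fluorine; one five-membered aromatic ring with 3 hetero atoms) in place of a group of 4 heavy atoms (1 carbon, 3 fluorine; no ring), on a carbonyl carbon. Two measured steps also exchange the group on a carbonyl carbon: a 1.9-fold lower number from compound 1 to compound 3 (0.28 log units; within the scatter) and a 2.6-fold higher number from compound 2 to compound 3 (0.42 log units; beyond the scatter). For the measured compounds named here, both are small to modest, and neither brings in an aromatic ring, so the new change has no close precedent. A modest step is the most that is expected, a lower number slightly favoured because compound 2 with a larger group on that carbonyl carbon gives 333 nM. Compound 4 is expected to give about 600 nM, within 200 nM to 2000 nM, an expected step of a 1.5-fold lower number from compound 3 to compound 4 (0.17 log units; within the scatter).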

Compound 4, half-maximal effective concentration: 103 nM
Compound 4: middle estimate off by 5.8-fold (0.77 log units), on the high side; the measured number lies below the stated range.
By their numbers in this assay, from the lowest: compound 4; then compound 2; then compounds 3 and 1 (each within the scatter of the next).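

In this assay, the group with a five-membered aromatic ring with 3 hetero atoms, on a carbonyl carbon whose other neighbour is the amide-type nitrogen in a ring, gives an 8.5-fold lower number from compound 3 to compound 4 (0.93 log units; beyond the scatter) and a 3.2-fold lower number from compound 2 to compound 4 (0.51 log units; beyond the scatter) and a 16-fold lower number from compound 1 to compound 4 (1.21 log units; beyond the scatter) as steps, all beyond the scatter. The position therefore accepts an aromatic ring, and the number falls further than with any earlier group there. Nothing available explains this fall.

Going by these compounds, it remains open whether the step belongs to the aromatic ring or to its fluorine-bearing side chain. A phenyl ring on that carbonyl carbon, or a hydrogen in place of that fluorine, would separate the two.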